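This account rests on a few compounds, and the source may have more. Where it says the series, first, only, none or still open, it means among the compounds named here.

Measured so far:
Compound 1, `CC(=O)N1CCc2ccccc2C1CC(c1ccccc1)c1ccccc1`, gives 130 nM in an assay on isolated protein for inhibition of melatonin receptor type 1B (Homo sapiens); on this read-out higher numbers stand for weaker inhibition and lower numbers for stronger inhibition.
Compound 2, `COc1cccc2c1CCN(C(C)=O)C2CC(c1ccccc1)c1ccccc1`, gives only a limit in this assay, > 1000 nM.

Going by the values given here, compound 1 holds the only actual number in this assay; the other result is a limit rather than a number, as the limit of > 1000 nM in this assay, at which 1 of the 2 values shown sits, records. Compound 3, `COc1ccc2c(c1)CCN(C(C)=O)C2CC(c1ccccc1)c1ccccc1`, differs from compound 1 in one place: methoxy in place of hydrogen on an aromatic carbon. Among the compounds with values here, one measured step bears on this change. The step of an at least 7.6-fold higher number from compound 1 to compound 2 (0.88 log units; beyond the scatter) also put a methoxy in place of hydrogen on an aromatic carbon of the shared core, though on a different carbon, and it moved the number clearly toward weaker inhibition, ending at a limit. By analogy, adding a methoxy to compound 1 at the position of compound 3 is expected to push the number upward as well, though how far is uncertain, since the site differs. Compound 3 is therefore estimated at 500 nM, with a range from 150 nM to 2000 nM. That estimate means an expected step of a 3.8-fold higher number from compound 1 to compound 3 (0.59 log units; beyond the scatter).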

Compound 3, half-maximal inhibitory concentration: 270 nM
For compound 3 the middle estimate is 1.9-fold (0.27 log units) above the measured one; the range from low to high includes it.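

In this assay, the new step, a 2.1-fold higher number from compound 1 to compound 3 (0.32 log units; beyond the scatter), shows that a methoxy on this aromatic carbon, meta to a fused ring and para to a fused ring, costs only a modest amount of inhibition, though the change is still beyond the usual scatter. Compound 3 therefore gives the series its first real size for this kind of change, and it points the same way as the step to compound 2: among the compounds shown, both replacements of hydrogen by methoxy on the aromatic ring of the shared core weaken inhibition, with neither going against that direction. The result for compound 2 is a limit rather than a number, so the difference between the two methoxy sites has a direction in the printed values but no exact size: the limit of > 1000 nM in this assay, at which 1 of the 3 values shown sits.

As far as these compounds go, what remains open is whether this modest cost belongs to methoxy in particular or would come with any replacement of hydrogen on this carbon. A hydroxyl, a fluorine atom, an amine or a longer ethoxy chain at the same place could fall on either side of compound 3, and the compounds shown give no way to tell which.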